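This account rests on a few compounds, and the source may have more. Where it says the series, first, only, none or still open, it means among the compounds named here.

Working notes on the series.

Three members have numbers in a physicochemical assay for lipophilicity, read by HPLC, measured as chromatographic lipophilicity, at pH 7.4; on this read-out lower numbers stand for lower lipophilicity and higher numbers for higher lipophilicity. Compound 1 `CC[C@H]1OC(=O)[C@H](C)[C@@H](O[C@H]2C[C@@](C)(OC)[C@@H](OCCCNC(C)=O)[C@H](C)O2)[C@H](C)[C@@H](O[C@@H]2O[C@H](C)C[C@H](N(C)C)[C@H]2O)[C@](C)(O)C[C@@H](C)CN(C)[C@H](C)[C@@H](O)[C@]1(C)O` gives 2.06 in this assay. Compound 3 `CC[C@H]1OC(=O)[C@H](C)[C@@H](O[C@H]2C[C@@](C)(OC)[C@@H](OCCCNC(=O)c3c(C)nn(C)c3Cl)[C@H](C)O2)[C@H](C)[C@@H](O[C@@H]2O[C@H](C)C[C@H](N(C)C)[C@H]2O)[C@](C)(O)C[C@@H](C)CN(C)[C@H](C)[C@@H](O)[C@]1(C)O` gives 2.52. Compound 2 `CC[C@H]1OC(=O)[C@H](C)[C@@H](O[C@H]2C[C@@](C)(OC)[C@@H](O)[C@H](C)O2)[C@H](C)[C@@H](O[C@@H]2O[C@H](C)C[C@H](N(C)C)[C@H]2O)[C@](C)(O)C[C@@H](C)CN(C)[C@H](C)[C@@H](OCCCNC(=O)c2c(C)nn(C)c2Cl)[C@]1(C)O` gives 3.01 and stands highest of the three, with compound 3 as its nearest neighbour and compound 1 furthest away, both gaps beyond the scatter. Among the compounds with values here, the one measured single-point step, a number 0.46 log units higher from compound 1 to compound 3 (beyond the scatter), covers the exchange of methyl for the 5-chloro-1,3-dimethyl-1H-pyrazol-4-yl group on the carbonyl carbon and is modest in size. Within the data shown here, compound 2 and compound 3 carry the same group on different parts of the shared core and their two values differ beyond the scatter; no single step connects them.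

Compound 4 `CC[C@H]1OC(=O)[C@H](C)[C@@H](O[C@H]2C[C@@](C)(OC)[C@@H](O)[C@H](C)O2)[C@H](C)[C@@H](O[C@@H]2O[C@H](C)C[C@H](N(C)C)[C@H]2O)[C@](C)(O)C[C@@H](C)CN(C)[C@H](C)[C@@H](OCCCNC(=O)C2CCC2)[C@]1(C)O` is not yet measured. It differs from compound 2 by cyclobutyl in place of 5-chloro-1,3-dimethyl-1H-pyrazol-4-yl on a carbonyl carbon. Among the measured compounds shown here, the step from compound 1 to compound 3 is the only measured reference, and it reads in the opposite sense: there the pyrazolyl entered, here it leaves, while cyclobutyl, which has no measured counterpart, enters. Expectation is therefore a small downward step, a number 0.26 log units lower from compound 2 to compound 4 (within the scatter), not far past the scatter. For compound 4 the estimate in this assay is 2.75, expected to lie between 2.35 and 3.15.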

Compound 4, distribution coefficient: 3.5
For compound 4 the middle estimate is 0.75 log units below the measured one, outside the stated range (above it).
By their numbers in this assay, from the lowest: compound 1; then compound 3; then compound 2; then compound 4.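

At this carbonyl carbon, the exchange gives a step in this assay that reads a number 0.49 log units higher from compound 2 to compound 4 (beyond the scatter) and shows that the 5-chloro-1,3-dimethyl-1H-pyrazol-4-yl group, with its 8 heavy atoms and 2 hydrogen-bond acceptors, is not needed for a high number here: cyclobutyl, with 4 heavy atoms, all carbon, reads higher. Within the data shown here, the only earlier step, a number 0.46 log units higher from compound 1 to compound 3 (beyond the scatter), went up as the pyrazolyl group entered in place of methyl, but on a different part of the shared core, so the series gives no single ordering of these groups by heavy-atom count, and compound 3 and compound 4 go against any such rule when taken together with their parents. Nothing measured on either group accounts for the size or direction of the new step.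

Going by these compounds, how a cyclopentyl or phenyl ring, or a carboxylic acid or primary amine at the end of a longer chain, would read on this carbonyl carbon remains open. Also open, on these data alone, is whether cyclobutyl gives a similar number on the other part of the shared core, where compound 3 carries the pyrazolyl group.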